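This account rests on a few compounds, and the source may have more. Where it says the series, first, only, none or still open, it means among the compounds named here.

Measured so far in an assay on CHO cells for antagonist activity at transient receptor potential cation channel subfamily V member 1 (Homo sapiens), read by FLIPR; on this read-out lower numbers stand for stronger inhibition and higher numbers for weaker inhibition:

compound 1, `CC(C(=O)NCc1ccc(C(F)(F)F)cc1N1CCN(c2ccccc2)CC1)c1ccc(NS(C)(=O)=O)c(F)c1`, gives 2 nM

compound 2, `CC(C(=O)NCc1ccc(C(F)(F)F)cc1-c1cccc(Cl)c1)c1ccc(NS(C)(=O)=O)c(F)c1`, gives 1 nM

Compound 2 holds the lowest of the two numbers in this assay. Going by the values given here, its only neighbour is compound 1, and the step of a 2.0-fold lower number from compound 1 to compound 2 (0.30 log units; within the scatter) lies within the scatter, so the two compounds cannot be told apart on these numbers.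

Compound 3, `COc1ccc(-c2cc(C(F)(F)F)ccc2CNC(=O)C(C)c2ccc(NS(C)(=O)=O)c(F)c2)cc1OC`, has not yet been measured. It differs from compound 2 at one place: 3,4-dimethoxyphenyl in place of 3-chlorophenyl on an aromatic carbon. Among the compounds with values here, the one measured step that bears on this change is a 2.0-fold lower number from compound 1 to compound 2 (0.30 log units; within the scatter), which exchanged a group at the same aromatic carbon and moved the number by no more than the scatter. Within the data shown here, with only that step to go on, the change from compound 2 to compound 3 is expected to give no step beyond the scatter in this assay, in either direction, so a 2.0-fold higher number from compound 2 to compound 3 (0.30 log units; within the scatter) is the expected outcome. For compound 3 the estimate in this assay is 2 nM, with a range from 0.5 nM to 8 nM.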

Compound 3, inhibition constant: 8.6 nM
For compound 3 the middle estimate is 4.3-fold (0.63 log units) below the measured one; measured number above the stated range.
By their numbers in this assay, from the lowest: compounds 2 and 1 (each within the scatter of the next); then compound 3.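

Up to this point, the aromatic carbon meta to the trifluoromethyl group had taken two quite different groups with no step beyond the scatter, so it could have seemed indifferent to what sits there. In this assay, the exchange of 3-chlorophenyl for 3,4-dimethoxyphenyl gives an 8.6-fold higher number from compound 2 to compound 3 (0.93 log units; beyond the scatter), and the exchange of 4-phenylpiperazin-1-yl for the same group gives a 4.3-fold higher number from compound 1 to compound 3 (0.63 log units; beyond the scatter), so inhibition does depend on the group at this carbon, and 3,4-dimethoxyphenyl is the weaker choice here by a modest margin in both comparisons. No separate measurement is available to explain this weakening.

The change to compound 3 removes a chlorine and adds two methoxy groups in a single step, so these compounds cannot show whether the loss follows the missing chlorine, one particular methoxy group, or the pair together. A ring with a single methoxy group, such as 3-methoxyphenyl, would help separate these cases, while a phenyl ring carrying a carboxylic acid or a dimethylamino group would test a very different kind of substituent at this carbon.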